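Removing one methyl from an amide nitrogen

A few compounds are considered here, and "the series" means these few. Any claim that something is new, unique, unknown or untested is made for them only; others in the source may bear on it.

compound 1 `CNC(=O)/C=C1\CCc2cc(F)c(F)cc21` gives 18 mg/kg
compound 2 `O=C(/C=C1\CCc2ccc(F)cc21)NC1CCCC1` gives 14 mg/kg

These two numbers come from a functional assay on the whole organism with Rattus norvegicus as the target (a higher number here means that more compound is needed for the effect, a lower number that less compound is needed), and lie within the usual scatter of each other, so compound 1 cannot be ranked against compound 2 on this evidence. Compound 3 `NC(=O)/C=C1\CCc2cc(F)c(F)cc21` keeps the core of compound 1 but has hydrogen in place of methyl on an amide-type nitrogen. For the measured compounds named here, no measured pair shows this change alone, so there is no direct guide to its effect. The only hint is indirect: compound 2 at 14 mg/kg differs from compound 1 in structure, yet their values stay within the scatter. A step beyond the scatter is therefore not expected, in either direction. The expected small change is a 1.2-fold lower number from compound 1 to compound 3 (0.08 log units; within the scatter) and would not stand out from the noise. Compound 3 is estimated at 15 mg/kg (range 6 mg/kg to 40 mg/kg).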

Compound 3, dose for half-maximal effect: 13 mg/kg
Estimate against measurement, compound 3: 1.2-fold (0.06 log units) above; low and high end bracket the measured number.
By their numbers in this assay, from the lowest: compounds 3, 2 and 1 (each within the scatter of the next).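

For the compounds shown here, compound 1 and compound 3 are the only pair here that differs in one place, and in this assay putting hydrogen in place of methyl on an amide-type nitrogen gives a 1.4-fold lower number from compound 1 to compound 3 (0.14 log units; within the scatter). On the core of compound 1, then, the methyl can be left off this nitrogen without a step that stands out from repeat measurements, something the comparison of compound 1 with compound 2 could not show, as those two differ in more than one place. Nothing measured here speaks to the reason for this match.

As far as these compounds go, this single pair spans only methyl and hydrogen, so an ethyl group, a longer chain or a chain ending in a hydroxyl on the same nitrogen remains open. From the compounds shown here alone, whether the same swap would give a similar step on another core also remains open.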